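Swapping Bromo for Methyl on a Weak Compound

The source may report more compounds than this note shows. Statements on the series, on what has been measured and on what is new or still open speak of the compounds shown alone.

In a functional assay on HCT-116 cells (Homo sapiens) for inhibition, read by MTT assay, with a stated time of 48 h (a lower number here means a stronger inhibitor, a higher number a weaker inhibitor), compound 2 (`COc1cc(NCc2ccc(Br)cc2)cc(OC)c1OC`) reads > 80000 nM and that entry is a limit of the assay, not a number. Compound 1 (`COc1ccc(CN(C(C)=O)c2cc(OC)c(OC)c(OC)c2)cc1O`), built differently, gives 270 nM in this assay and so shows that the assay can return a true number for a compound of this set. Compound 3 (`COc1cc(NCc2ccc(C)cc2)cc(OC)c1OC`) differs from compound 2 in one place (methyl in place of bromo on an aromatic carbon). Compound 3 carries methyl where compound 2 carries bromo, and the site is an aromatic carbon para to a large group. For the measured compounds named here, no measured pair shows this swap, and the expectation rests on compound 2 with its limit > 80000 nM alone. The step of an at least 1.1-fold lower number from compound 2 to compound 3 (0.05 log units; that floor lies within the scatter) is expected to be no larger than the usual scatter, in no clear direction. For compound 3 the estimate is 70000 nM (expected range 20000 nM to 200000 nM), and the assay may again report only a limit.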

Compound 3, half-maximal inhibitory concentration: > 80000 nM
Compound 3 ended at the assay's limit (the forecaster's own chance of this, stated with the estimate: 65%); at least 1.1-fold (0.05 log units) between middle value and limit.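

No step can be read from compound 2 to compound 3, because both entries are limits of the assay and not numbers: the limit of > 80000 nM in this assay, at which 2 of the 3 values shown sit.

From the compounds shown here alone, whether 4-bromophenyl and 4-methylphenyl give different readings in this assay stays open, as neither compound returns a true number there.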